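A few compounds are considered here, and "the series" means these few. Any claim that something is new, unique, unknown or untested is made for them only; others in the source may bear on it.

Compound 1 `CCCCOc1ccc(OCCCNC(C)C)cc1` gives 56 nM in an assay for inhibition of squalene synthase (Rattus norvegicus), using microsomes; a lower number here means a stronger inhibitor, a higher number a weaker inhibitor. Compound 2 `CC(C)NCCCOc1ccc(-c2ccccc2)cc1` gives 170 nM. Compound 3 `C=CCc1cc(-c2ccccc2)ccc1OCCCNC(C)C` gives 0.004 nM.

Compound 2 holds the highest number of the three, and so is the weakest inhibitor here: the step of a 3.0-fold higher number from compound 1 to compound 2 (0.48 log units; beyond the scatter) lifts it above compound 1, and the step of a 43000-fold lower number from compound 2 to compound 3 (4.63 log units; beyond the scatter) sets compound 3 far beneath it. Compound 4 `CC(C)NCCCOc1ccc(-c2cccnc2)cc1` differs from compound 2 by pyridin-3-yl in place of phenyl on an aromatic carbon. Among the compounds with values here, no measured step bears on this exchange: a 3.0-fold higher number from compound 1 to compound 2 (0.48 log units; beyond the scatter) replaces the whole group at this position, and a 43000-fold lower number from compound 2 to compound 3 (4.63 log units; beyond the scatter) adds an allyl elsewhere on the core. With nothing to guide direction, a step of a 1.2-fold higher number from compound 2 to compound 4 (0.07 log units; within the scatter) is expected, within the scatter. Compound 4 is therefore estimated at 200 nM, with a range from 60 nM to 700 nM.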

Compound 4, half-maximal inhibitory concentration: > 2500 nM
Compound 4 ended at the assay's limit (the forecaster's own chance of this, stated with the estimate: 5%); at least 12-fold (1.09 log units) between middle value and limit.
By their numbers in this assay, from the lowest: compound 3; then compound 1; then compound 2. At a limit, above all of these: compound 4.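

For compound 4 the reading is a limit of the assay, not a number: the limit of > 2500 nM in this assay, at which 1 of the 4 values shown sits. Even so, this position proves sensitive to a change of one ring atom, as pyridin-3-yl for phenyl gives an at least 14-fold higher number from compound 2 to compound 4 (1.16 log units; beyond the scatter), and pyridin-3-yl for butoxy gives an at least 44-fold higher number from compound 1 to compound 4 (1.64 log units; beyond the scatter). The earlier exchange of butoxy for phenyl here had been only a modest step, so the ring nitrogen matters more at this position than that exchange suggested.

Going by these compounds, it remains open whether pyridin-4-yl or pyrimidin-5-yl would fare the same here. Also open, on these data alone, is whether an allyl group on the core, as in compound 3, would restore strength to a compound carrying pyridin-3-yl.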